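A Smaller Acyl Group on the Hydroxamate of Compound 3

The compounds below may be only part of what the source reports. "The series", "measured", "known", "first", "only" and "open" are said of these compounds alone.

Of the compounds shown here, three have so far been measured in an assay on RBL cells for inhibition of Polyunsaturated fatty acid 5-lipoxygenase (Rattus norvegicus); on this read-out lower numbers stand for stronger inhibition and higher numbers for weaker inhibition. Compound 1 `CC(=O)N(O)C(C)c1ccc(OCCc2ccccc2)cc1` gives 410 nM, compound 2 `COc1ccc2cc(-c3cc4cc(C(C)N(O)C(C)=O)ccc4o3)ccc2c1` gives 120 nM, and compound 3 `COc1cccc(OC)c1C(=O)N(O)C(C)c1ccc2oc(-c3ccccc3)cc2c1` gives 3000 nM. Compound 3 therefore stands at the highest number of the three; its gap to compound 1 and its larger gap to compound 2 both lie beyond the usual scatter, so compound 3 is the weakest inhibitor of the measured set.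

Compound 4 `CCOC(=O)CCC(=O)N(O)C(C)c1ccc2oc(-c3ccccc3)cc2c1` has not yet been measured. It differs from compound 3 in one place: 2-(ethoxycarbonyl)ethyl in place of 2,6-dimethoxyphenyl on a carbonyl carbon. Among the measured compounds shown here, no pair of measured compounds shows this change, so no measured step can be drawn on directly. What the measured set does show is that compound 1 and compound 2, which carry only a small acetyl group on the same carbonyl carbon, give clearly lower numbers than compound 3 with its 2,6-dimethoxyphenyl there. On that basis compound 4 is expected to move toward lower numbers, with an estimated step of a 3.8-fold lower number from compound 3 to compound 4 (0.57 log units; beyond the scatter). For the measured compounds named here, no measured compound carries the 2-(ethoxycarbonyl)ethyl chain, so the size of this step is uncertain. The estimate for compound 4 in this assay is 800 nM, within a range from 200 nM to 3500 nM.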

Compound 4, half-maximal inhibitory concentration: 50 nM
Beside the measured number, compound 4's estimate is 16-fold (1.20 log units) above it, and the stated range ends above it.
By their numbers in this assay, from the lowest: compound 4; then compound 2; then compound 1; then compound 3.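

In this assay, among the compounds shown here, putting 2-(ethoxycarbonyl)ethyl in place of 2,6-dimethoxyphenyl on the carbonyl carbon gives a 60-fold lower number from compound 3 to compound 4 (1.78 log units; beyond the scatter), the first measured step at this position, and a large one. It shows that the group on this carbonyl carbon can strongly change the read-out while the rest of the structure stays the same, and that a low number here does not depend on a small acetyl group, as the entering chain has 7 heavy atoms and no ring, while the leaving group has 10 heavy atoms and an aromatic ring, with the count of hydrogen-bond acceptors the same on both sides. Nothing in the data explains why the step is so large.

The compounds shown leave open whether the step comes from losing the 2,6-dimethoxyphenyl ring or from the ethoxycarbonyl part of the new chain, which a plain butyl chain or a carboxylic acid in place of the ethyl ester could help to separate. They also leave open how an acetyl group would stand on the core of compound 3.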